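A Furan Ring in Place of a Methyl Group

The compounds below may be only part of what the source reports. "The series", "measured", "known", "first", "only" and "open" are said of these compounds alone.

Of the compounds shown here, three sharing one core have been tested in a functional assay on SH-SY5Y cells (Homo sapiens) for antiproliferative activity, with a stated time of 24 h, tested at 50 ug/mL; a higher number here means a stronger effect of the compound at the concentration tested, a lower number a weaker effect. Compound 1 `CC1=Cc2c(cc(C)oc2=O)OC1C` gives 53.8%, compound 2 `CCC1C=Cc2c(cc(C)oc2=O)O1` gives 43.7%, and compound 3 `CCCCCCCCC1C=Cc2c(cc(C)oc2=O)O1` gives 83.3%. Compound 1 thus stands second highest of the three: its number lies above that of compound 2 and below that of compound 3, and both gaps are beyond the usual scatter of this kind of measurement.

Compound 4 `CC1=Cc2c(cc(C)oc2=O)OC1c1ccco1` differs from compound 1 in a single place: furan-2-yl in place of methyl on a saturated ring carbon. Among the compounds with values here, no measured pair makes exactly this exchange. Within the data shown here, the only measured step, a number 39.6 percentage points higher from compound 2 to compound 3 (beyond the scatter), shows that adding a larger group on a saturated chain carbon, two bonds along the chain from a saturated ring carbon, went with a markedly higher number in this assay. Compound 4 likewise carries a larger group on a saturated ring carbon, although that group is an aromatic ring rather than a chain, so the measured step is only a rough guide. A rise beyond the scatter is expected, though smaller than the measured one. For compound 4 the expected step is a number 12.2 percentage points higher from compound 1 to compound 4 (beyond the scatter). The estimate for compound 4 is 66%, with a likely range from 46% to 86%.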

Compound 4, a percentage reported as inhibition, at one concentration (the size of the read-out at that concentration, not a potency): 64.4%
The estimate for compound 4 lay 1.6 percentage points above the measured number, and the stated range covers the measured number.
By their numbers in this assay, from the lowest: compound 2; then compound 1; then compound 4; then compound 3.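

On the saturated ring carbon next to the ring oxygen, putting furan-2-yl in place of methyl raises the number in this assay (a number 10.6 percentage points higher from compound 1 to compound 4 (beyond the scatter)). Within the data shown here, the earlier step lay on a chain, so this is the first reading at the ring carbon itself: a single methyl can give way to a five-membered aromatic ring with one hetero atom, and the number goes up rather than down. No measurement at hand explains why the number rises.

The compounds shown cannot tell whether the furan oxygen matters or whether any larger group at this carbon would do the same: phenyl there would separate the aromatic ring from its oxygen, and hexyl there would show whether a chain on the ring carbon goes with a rise as well. Also open, from the compounds shown here alone, is what happens at the ring atom that bears a methyl group, where an ethyl group or a hydrogen in place of that methyl would show how much this second position contributes.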